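The compounds below may be only part of what the source reports. "The series", "measured", "known", "first", "only" and "open" are said of these compounds alone.

Measured so far in an ADME assay on RAW264.7 cells (Mus musculus) for cytotoxicity, read by MTT assay, with a stated time of 24 h, in the presence of a further agent that is not named here (a lower number here means a stronger inhibitor, a higher number a weaker inhibitor), are three compounds, each reported only as a limit:

Compound 1 `CCCOc1ccc(C(O)C2OC(=O)c3c(OC)cc(OC)cc32)cc1` gives > 40000 nM
Compound 2 `COCCCOc1ccc(C(O)C2OC(=O)c3c(OC)cc(OC)cc32)cc1` gives > 40000 nM
Compound 3 `COc1cc(OC)c2c(c1)C(C(O)c1ccc(OCc3ccccc3)cc1)OC2=O` gives > 40000 nM

Compound 3 has no number, only the limit > 40000 nM, which is the place of the whole set: the limit of > 40000 nM in this assay, at which 3 of the 3 values shown sit.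

Compound 4 `COc1cc(OC)c2c(c1)C(C(O)c1ccc(OCc3ccc(C#N)cc3)cc1)OC2=O` differs from compound 3 by one change: cyano in place of hydrogen on an aromatic carbon. Two measured changes touch the same side chain, a step that the two limits leave unreadable from compound 1 to compound 3 and a step that the two limits leave unreadable from compound 2 to compound 3, but neither has a readable size. No step beyond the scatter is therefore expected in this assay, and no direction is expected. The expected outcome is a number no higher from compound 3 to compound 4 (the limit leaves the size open), probably unreadable again.

Compound 4 is estimated at 40000 nM, with an expected range from 20000 nM to 80000 nM, most likely reported as a limit again.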

Compound 4, half-maximal inhibitory concentration: > 40000 nM
Compound 4 gave a limit, no number; the forecaster's own chance of this, stated with the estimate: 85%; the middle value sits exactly at the limit.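

Compound 4, like compound 1, compound 2 and compound 3, is reported only as a limit, so no new step from any of them to compound 4 can be read: the limit of > 40000 nM in this assay, at which 4 of the 4 values shown sit.

What the compounds shown leave open is whether any of them has a measurable half-maximal inhibitory concentration in this assay, and whether the cyano group makes any difference there.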